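Moving a Fluorinated Group Around a Pendant Phenyl Ring

The source may hold more compounds than are shown below. What is called first, only, known or untested is meant among the compounds shown, and "the series" means these compounds.

Two compounds share one core and differ only in the aryl group attached to an aromatic nitrogen. Compound 1, `Cc1cc(=O)n(-c2ccc(F)cc2)nc1C(=O)Nc1ccc(Oc2ncnc3[nH]ccc23)cc1`, carries a 4-fluorophenyl group there. In a functional assay on A549 cells (Homo sapiens) for cytotoxicity, read by MTT assay, with a stated time of 72 h (a lower number here means a stronger inhibitor, a higher number a weaker inhibitor), compound 1 gives only a limit, > 60000 nM, and this sits at the limit of > 60000 nM in this assay, at which 1 of the 2 values shown sits. Compound 2, `Cc1cc(=O)n(-c2ccccc2OC(F)(F)F)nc1C(=O)Nc1ccc(Oc2ncnc3[nH]ccc23)cc1`, carries a 2-(trifluoromethoxy)phenyl group instead. In this assay, within the data shown here, compound 2 gives 16200 nM, the only plain number among the values shown. The step of an at least 3.7-fold lower number from compound 1 to compound 2 (0.56 log units; beyond the scatter) shows that exchanging the fluorophenyl for the trifluoromethoxyphenyl made the compound a stronger inhibitor, at least modestly.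

Compound 3, `Cc1cc(=O)n(-c2cccc(C(F)(F)F)c2)nc1C(=O)Nc1ccc(Oc2ncnc3[nH]ccc23)cc1`, has not been measured. It differs from compound 2 by 3-(trifluoromethyl)phenyl in place of 2-(trifluoromethoxy)phenyl on an aromatic nitrogen. Among the measured compounds shown here, only one measured step bears on this change, an at least 3.7-fold lower number from compound 1 to compound 2 (0.56 log units; beyond the scatter), and it concerns a different pair of groups; both compound 2 and compound 3 carry a fluorinated aryl group, so the expected step of a 1.1-fold lower number from compound 2 to compound 3 (0.03 log units; within the scatter) is small and not clearly beyond the scatter in either direction. Compound 3 is therefore estimated at 15000 nM, within a range from 5000 nM to 50000 nM.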

Compound 3, half-maximal inhibitory concentration: 7570 nM
Compound 3: middle estimate off by 2.0-fold (0.30 log units), on the high side; the range from low to high includes it.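

The exchange at this position gives, in this assay, a 2.1-fold lower number from compound 2 to compound 3 (0.33 log units; beyond the scatter), so two fluorinated aryl groups on the same aromatic nitrogen are not interchangeable, and compound 3 is the strongest inhibitor of the three at 7570 nM. Against the 4-fluorophenyl group, the 3-(trifluoromethyl)phenyl group gives an at least 7.9-fold lower number from compound 1 to compound 3 (0.89 log units; beyond the scatter), which is a larger step than the one seen earlier with the 2-(trifluoromethoxy)phenyl group. Compound 1 gives a limit of the assay rather than a number, so this step marks only a minimum size: the limit of > 60000 nM in this assay, at which 1 of the 3 values shown sits.

The change from compound 2 to compound 3 removes the oxygen of the side group and also moves the fluorinated group to another place on the phenyl ring, so these compounds cannot show which of the two matters; 2-(trifluoromethyl)phenyl and 3-(trifluoromethoxy)phenyl groups would separate them. From the compounds shown here alone, it also remains open whether fluorine is needed at all, a question that a 3-methylphenyl group or a phenyl ring bearing an amine at the same place could address.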